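Moving the ring nitrogen in an amide-linked pyridine

The compounds below may be only part of what the source reports. "The series", "measured", "known", "first", "only" and "open" are said of these compounds alone.

Of the compounds shown here, three sharing one core have been measured in a physicochemical assay for solubility, in phosphate buffer, measured as kinetic solubility, with a stated time of 1 h, at pH 7.4; on this read-out higher numbers stand for higher solubility and lower numbers for lower solubility. Compound 1 `COc1ccc(NC(=O)COc2cc(C)nc3ccc(OC)cc23)cc1` gives 108000 nM, and compound 2 `COc1ccc2nc(C)cc(OCC(=O)Nc3ccc(F)cc3)c2c1` gives 104000 nM; the step of a 1.0-fold lower number from compound 1 to compound 2 (0.02 log units; within the scatter) lies within the scatter. Compound 3 `COc1ccc2nc(C)cc(OCC(=O)Nc3ccccn3)c2c1` gives 29000 nM, the lowest of the three numbers, reached by the steps of a 3.7-fold lower number from compound 1 to compound 3 (0.57 log units; beyond the scatter) and a 3.6-fold lower number from compound 2 to compound 3 (0.55 log units; beyond the scatter).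

Compound 4 `COc1ccc2nc(C)cc(OCC(=O)Nc3ccncc3)c2c1` differs from compound 3 by a single change: pyridin-4-yl in place of pyridin-2-yl on an amide-type nitrogen. Neither measured step concerns this kind of change; both replaced a substituted phenyl group by a pyridin-2-yl group on the amide-type nitrogen, whereas here the nitrogen simply moves within the ring. The measured steps therefore bear only loosely on it, and no direction can be read from them with confidence. The expectation is a step no larger than those seen so far, given as a 1.6-fold higher number from compound 3 to compound 4 (0.19 log units; within the scatter), pointing slightly upward. For compound 4 the estimate in this assay is 45000 nM, with a range from 18000 nM to 120000 nM.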

Compound 4, solubility: 91500 nM
Compound 4: middle estimate off by 2.0-fold (0.31 log units), on the low side; the measured number falls inside the stated range.
By their numbers in this assay, from the lowest: compound 3; then compounds 4, 2 and 1 (each within the scatter of the next).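

In this assay, the two compounds hold the same atoms joined differently, yet pyridin-4-yl in place of pyridin-2-yl on the amide-type nitrogen gives a 3.2-fold higher number from compound 3 to compound 4 (0.50 log units; beyond the scatter), so moving the ring nitrogen alone can shift the number at this position. Against the phenyl compounds, the steps of a 1.1-fold lower number from compound 2 to compound 4 (0.06 log units; within the scatter) and a 1.2-fold lower number from compound 1 to compound 4 (0.07 log units; within the scatter) both lie within the scatter, so the earlier drop on going to a pyridine does not extend to every pyridine: among these four, only compound 3 stands apart. Nothing measured here explains the gap between the two pyridines.

Left open is where pyridin-3-yl would fall in this assay. Also open, going by these compounds, is whether a pyridine carrying an amine or a carboxylic acid would stay with compound 3 or with compound 4.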